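The compounds below may be only part of what the source reports. "The series", "measured", "known", "first", "only" and "open" are said of these compounds alone.

Of the compounds shown here, two have numbers so far. In a functional assay on the whole organism (Abdomen, strain Swiss) for inhibition, with Mus musculus as the target, with stated times of 30 min, 10 min and 5 min, at a dose of 40 mg/kg by the oral route (on this read-out lower numbers stand for a weaker effect and higher numbers for a stronger effect at the one dose given), compound 1 `C=Cc1c(CCCC)nn(CCCN2CCN(c3ccc(C)cc3)CC2)c(=O)c1N` gives 48%. In this assay compound 2 `Cc1c(C#N)c(-c2ccccc2)nn1CCCN1CCN(c2ccc(F)cc2)CC1` gives 51%, the larger of the two numbers, though the gap to compound 1 lies within the scatter, so the two cannot be told apart. Compound 3 `Cc1c(C#N)c(-c2ccccc2)nn1CCCN1CCN(c2cccc(Cl)c2)CC1` has not been measured. It differs from compound 2 in one place: 3-chlorophenyl in place of 4-fluorophenyl on an amine nitrogen in a ring. Going by the values given here, no measured pair shows what such a swap does, so the expected step is a number 1 percentage points lower from compound 2 to compound 3 (within the scatter), none beyond the scatter. Compound 3 is estimated at 50%, between 30% and 70%.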

Compound 3, a percentage reported as inhibition, in the whole organism at one dose (the size of the read-out at that dose, not a potency): 23%
Compound 3: middle estimate off by 27 percentage points, on the high side; the measured number lies below the stated range.
By their numbers in this assay, from the lowest: compound 3; then compounds 1 and 2 (each within the scatter of the next).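

In this assay, the group on this amine nitrogen in a ring clearly matters: 3-chlorophenyl in place of 4-fluorophenyl gives a number 28 percentage points lower from compound 2 to compound 3 (beyond the scatter) with the rest of the molecule unchanged. The two groups have the same count of heavy atoms, and neither has a hydrogen-bond donor or acceptor, so these counts do not separate them. No available measurement explains the step.

From the compounds shown here alone, the halogen and its ring position change together, so the effect of each remains open. A plain phenyl or 4-chlorophenyl on the same nitrogen would help separate them.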